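The source may hold more compounds than are shown below. What is called first, only, known or untested is meant among the compounds shown, and "the series" means these compounds.

Measured so far:
- compound 1 `O=C(NCc1ccc(S(=O)(=O)c2cc(F)cc(F)c2)cc1)N1Cc2ccncc2C1`: 16000 nM
- compound 2 `CCC(=O)N1CCC(S(=O)(=O)c2ccc(CNC(=O)N3Cc4ccncc4C3)cc2)CC1`: 216000 nM

Compound 1 stands lowest of the two numbers in a physicochemical assay for solubility, in phosphate buffer, with a stated time of 24 h, at pH 7.4, tested at 100 uM; on this read-out higher numbers stand for higher solubility and lower numbers for lower solubility; its nearest neighbour is compound 2, and the change a 14-fold higher number from compound 1 to compound 2 (1.13 log units; beyond the scatter) is large and beyond the scatter.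

The step under consideration goes from compound 1 to compound 3 `O=C(NCc1ccc(S(=O)(=O)N2CCC(N3CCCC3)CC2)cc1)N1Cc2ccncc2C1`. The structural change is 4-(pyrrolidin-1-yl)piperidin-1-yl in place of 3,5-difluorophenyl on a sulfonyl sulfur.

Among the measured compounds shown here, one measured step bears on this: the move from compound 1 to compound 2 also replaced the 3,5-difluorophenyl group on the sulfonyl sulfur with a saturated six-membered ring bearing a nitrogen, and gave a 14-fold higher number from compound 1 to compound 2 (1.13 log units; beyond the scatter). The change to compound 3 likewise puts a saturated ring system with nitrogen in place of the 3,5-difluorophenyl on the sulfonyl sulfur, here 4-(pyrrolidin-1-yl)piperidin-1-yl. A large rise beyond the scatter is therefore expected, of a size at least comparable to the measured step. The expected step is a 16-fold higher number from compound 1 to compound 3 (1.19 log units; beyond the scatter). For compound 3 the estimate in this assay is 250000 nM, with a range from 60000 nM to 800000 nM.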

Compound 3, solubility: 6200 nM
The estimate for compound 3 lay 40-fold (1.61 log units) above the measured number; measured number below the stated range.
By their numbers in this assay, from the lowest: compound 3; then compound 1; then compound 2.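

In this assay, swapping 3,5-difluorophenyl on the sulfonyl sulfur for a saturated ring group does not move the number in one fixed direction: 4-(pyrrolidin-1-yl)piperidin-1-yl gives a 2.6-fold lower number from compound 1 to compound 3 (0.41 log units; beyond the scatter), against the rise of a 14-fold higher number from compound 1 to compound 2 (1.13 log units; beyond the scatter) with 1-propanoylpiperidin-4-yl. Removing the aromatic ring therefore does not by itself set the outcome at this position, and the two saturated groups stand far apart, with a 35-fold lower number from compound 2 to compound 3 (1.54 log units; beyond the scatter), a larger gap than either step away from compound 1. No measurement on hand accounts for the direction or size of these steps.

From the compounds shown here alone, what remains open is which feature of the two saturated groups separates compound 2 from compound 3, since the propanoyl group, the pyrrolidine ring and the atom through which the piperidine is joined all change together in that step. A plain piperidin-1-yl or a morpholine on the sulfonyl sulfur would help separate these features, and a carboxylic acid on the piperidine ring would extend the comparison to a further type of group.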